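The source may report more compounds than this note shows. Statements on the series, on what has been measured and on what is new or still open speak of the compounds shown alone.

Measured so far:
compound 1 `N#CN1CC(OCc2ccc(Oc3ccccc3)cc2)C1` — in an assay on isolated protein for inhibition of N-acylethanolamine-hydrolyzing acid amidase (Homo sapiens), read by fluorescence, with a stated time of 90 min (on this read-out higher numbers stand for weaker inhibition and lower numbers for stronger inhibition), compound 1 gives 1.1 nM
compound 2 `N#CN1CC(OCc2ccc(Oc3ccccc3)cc2-c2ccccc2)C1` — in this assay compound 2 gives 8.5 nM
compound 3 `COc1ccc(-c2cc(Oc3ccccc3)ccc2COC2CN(C#N)C2)cc1` — in this assay compound 3 gives 5.7 nM

Compound 3 holds the second highest number of the three: the gap a 1.5-fold lower number from compound 2 to compound 3 (0.17 log units; within the scatter) is within the scatter, whereas a 5.2-fold higher number from compound 1 to compound 3 (0.71 log units; beyond the scatter) is beyond it. Compound 4 `N#Cc1ccccc1-c1cc(Oc2ccccc2)ccc1COC1CN(C#N)C1` differs from compound 3 by 2-cyanophenyl in place of 4-methoxyphenyl on an aromatic carbon. Going by the values given here, two steps bear on it: a 7.7-fold higher number from compound 1 to compound 2 (0.89 log units; beyond the scatter) and a 5.2-fold higher number from compound 1 to compound 3 (0.71 log units; beyond the scatter) show that an aryl group on this carbon costs modestly, while a 1.5-fold lower number from compound 2 to compound 3 (0.17 log units; within the scatter) shows that changing the substituent on that aryl group stays within the scatter. A step of similar size is therefore expected for compound 4, namely a 1.2-fold higher number from compound 3 to compound 4 (0.09 log units; within the scatter), not beyond the scatter. Compound 4 is estimated at 7 nM, within 2.5 nM to 20 nM.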

Compound 4, half-maximal inhibitory concentration: 6.6 nM
Beside the measured number, compound 4's estimate is 1.1-fold (0.03 log units) above it; the measured number falls inside the stated range.
By their numbers in this assay, from the lowest: compound 1; then compounds 3, 4 and 2 (each within the scatter of the next).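

At the carbon ortho to the ((1-cyanoazetidin-3-yl)oxy)methyl group, a third aryl group, 2-cyanophenyl, again carries a modest cost against hydrogen (a 6.0-fold higher number from compound 1 to compound 4 (0.78 log units; beyond the scatter)). Exchanging 4-methoxyphenyl for 2-cyanophenyl stays within the scatter (a 1.2-fold higher number from compound 3 to compound 4 (0.06 log units; within the scatter)), as does cyano in place of hydrogen on the phenyl ring (a 1.3-fold lower number from compound 2 to compound 4 (0.11 log units; within the scatter)), so neither the substituent's identity nor its ring position separates compound 2, compound 3 and compound 4. No evidence on the cause of these steps is available. Still open, from the compounds shown here alone, is whether an amine or a carboxylic acid on this aryl ring, or a short alkyl chain in place of the aryl group, would return the number toward that of compound 1.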